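The compounds below may be only part of what the source reports. "The series", "measured", "known", "first", "only" and "open" are said of these compounds alone.

Three close relatives of one chlorinated bicyclic core, each carrying a benzyl group that bears a chloromethyl arm, have been tested for their effect on the growth of a human kidney cancer cell line. In a functional assay on SN12C cells (Homo sapiens) for cytotoxicity, read by sulforhodamine B assay, with a stated time of 48 h (on this read-out higher numbers stand for weaker inhibition of growth and lower numbers for stronger inhibition of growth), compound 1, `ClCc1ccc(Cn2cnc3c(Cl)ncnc32)cc1`, gives 2340 nM. In this assay compound 2, `ClCc1cccc(Cn2cnc3c(Cl)nc(Cl)nc32)c1`, gives 4670 nM. In this assay compound 3, `ClCc1ccccc1Cn1cnc2nc(Cl)nc(Cl)c21`, gives 2570 nM. Compound 3 thus sits among its two companions: its number is closest to that of compound 1 and furthest from that of compound 2, yet both gaps fall within the scatter of repeated measurements, so nothing separates the three with confidence.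

Compound 4, `ClCc1ccccc1Cn1cnc2ncnc(Cl)c21`, has not yet been measured. It differs from compound 3 in one place: hydrogen in place of chloro on an aromatic carbon. In words, a hydrogen stands where compound 3 carries a chloro group, on the carbon of the six-membered aromatic ring that lies between two ring nitrogen atoms, while the second chloro group and the benzyl arm stay as they are.

Because compound 1, which also lacks a chloro group at a comparable position, gives 2340 nM, no step beyond the scatter is expected in this assay. Compound 4 is therefore estimated at 2500 nM, within a range from 1200 nM to 5500 nM. The step of a 1.0-fold lower number from compound 3 to compound 4 (0.01 log units; within the scatter) is expected to stay within the usual scatter.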

Compound 4, concentration for total growth inhibition: 8510 nM
Compound 4: middle estimate off by 3.4-fold (0.53 log units), on the low side, outside the stated range (above it).
By their numbers in this assay, from the lowest: compounds 1, 3, 2 and 4 (each within the scatter of the next, the first and the last beyond it).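

Going by these compounds alone, until now, no two tested compounds differed in only one place, so no single group could be judged on its own; compound 3 and compound 4 provide the first such comparison. In this assay the exchange of chloro for hydrogen on the aromatic carbon between two ring nitrogen atoms gives a 3.3-fold higher number from compound 3 to compound 4 (0.52 log units; beyond the scatter) and so shows weaker inhibition of growth once this chloro group is gone, a modest change but one larger than ordinary repeat variation. This makes the position one where the substituent matters for this read-out, although nothing available here explains the shift.

As far as these compounds go, this is a single pair, with the second chloro group and the chloromethyl-bearing benzyl arm held as they stand in compound 3, so it remains open whether the same exchange would have a similar effect with the arm placed differently on its ring. From the compounds shown here alone, it is also open whether a fluoro group, a methoxy group or an amine on this same carbon would give a number closer to that of compound 3 or to that of compound 4.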